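Aryloxy variation and cytotoxicity within the shared core

The source may report more compounds than this note shows. Statements on the series, on what has been measured and on what is new or still open speak of the compounds shown alone.

Measured compounds:
compound 1, `Cc1cc(C#N)cc(C)c1Oc1nc(Nc2ccc(C#N)cc2)nc2ccccc12`, 203000 nM
compound 2, `N#Cc1ccc(Nc2nc(Oc3ccc(Cl)cc3)c3ccccc3n2)cc1`, 198000 nM
compound 3, `Cc1cc(C)c(Oc2nc(Nc3ccc(C#N)cc3)nc3ccccc23)c(C)c1`, > 34000 nM

In an ADME assay on MT4 cells (Homo sapiens) for cytotoxicity, read by MTT assay, with a stated time of 4 days (a lower number here means that less compound is tolerated, a higher number that more compound is tolerated), compound 1 gives 203000 nM. In this assay compound 2 gives 198000 nM, and the step of a 1.0-fold lower number from compound 1 to compound 2 (0.01 log units; within the scatter) shows that exchanging the aryl group on the oxygen leaves the read-out where it was. For compound 3 the result > 34000 nM is a limit of the assay, not a number, as noted in the limit of > 34000 nM in this assay, at which 1 of the 3 values shown sits. Because of that limit the steps a step that the limit leaves unreadable from compound 1 to compound 3 and a step that the limit leaves unreadable from compound 2 to compound 3 cannot be sized, so compound 3 stands only as a floor in this assay.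

Compound 4, `COc1ccccc1Oc1nc(Nc2ccc(C#N)cc2)nc2ccccc12`, differs from compound 3 in one place: 2-methoxyphenyl in place of 2,4,6-trimethylphenyl on an oxygen on an aromatic ring. Within the data shown here, the only readable step bearing on this position is a 1.0-fold lower number from compound 1 to compound 2 (0.01 log units; within the scatter), which lay within the scatter; the steps from compound 3 are unreadable. No step beyond the scatter is therefore expected for compound 4 in this assay relative to where compounds 1 and 2 sit. Compound 4 is estimated at 150000 nM, with a range from 35000 nM to 300000 nM. This estimate corresponds to the expected step that the limit leaves unreadable from compound 3 to compound 4.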

Compound 4, half-maximal cytotoxic concentration: 150000 nM
The estimate for compound 4 equals the measured number at the digits printed, and the stated range covers the measured number.
By their numbers in this assay, from the lowest: compounds 4, 2 and 1 (each within the scatter of the next).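

In this assay, 2-methoxyphenyl on the oxygen gives a 1.3-fold lower number from compound 2 to compound 4 (0.12 log units; within the scatter) and a 1.4-fold lower number from compound 1 to compound 4 (0.13 log units; within the scatter). The position therefore now holds three readable aryl groups within the scatter of each other, and the set includes one, 2-methoxyphenyl, that counts a hydrogen-bond acceptor. The steps that involve compound 3 cannot be read, since compound 3 is held only by a limit: the limit of > 34000 nM in this assay, at which 1 of the 4 values shown sits.

Going by these compounds, whether a group of another kind on the oxygen, such as a longer alkyl chain or a phenyl ring bearing a carboxylic acid, would shift the number beyond the scatter stays open. Also open, on these data alone, is where compound 3 sits relative to compounds 1, 2 and 4, and whether a change on the shared core outside this position would move the number.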